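The compounds below may be only part of what the source reports. "The series", "measured", "known", "first", "only" and "open" are said of these compounds alone.

Working notes on the series, read in a toxicity assay on NIH3T3 cells (Mus musculus) for cytotoxicity, read by resazurin assay; a higher number here means that more compound is needed for the effect, a lower number that less compound is needed. Compound 1 `CCC(=O)c1ccc(NCc2cncn2Cc2ccc(-c3ccccc3)cc2)cc1-c1ccccc1` gives > 10000 nM, which is a limit of the assay. Compound 2 `c1ccc(-c2ccc(Cn3cncc3CNc3ccc(N4CCCCC4)c(-c4ccccc4)c3)cc2)cc1` gives > 1000 nM, which is also a limit, so compound 2 has no exact number. Compound 3 `c1ccc(-c2ccc(Cn3cncc3CNc3ccc(-c4onc5ccccc45)c(-c4ccccc4)c3)cc2)cc1` differs from compound 2 at one place, on an aromatic carbon ortho to a phenyl group: a group of 9 heavy atoms (7 carbon, 1 nitrogen, 1 oxygen; one five-membered aromatic ring with 2 hetero atoms, one six-membered aromatic ring of carbon only) in place of a group of 6 heavy atoms (5 carbon, 1 nitrogen; one six-membered non-aromatic ring with 1 hetero atom), on an aromatic carbon. The piperidin-1-yl group leaves, and a larger group with two aromatic rings enters. Among the compounds with values here, the only measured step at this substituent is a step that the two limits leave unreadable from compound 1 to compound 2. It offers neither a size nor a direction to carry over, so the expectation rests on the two limits alone, with no clear shift in this assay anticipated. The expected change is a step that the limit leaves unreadable from compound 2 to compound 3. For compound 3 the estimated value is 4000 nM, with an expected range from 1000 nM to 15000 nM.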

Compound 3, half-maximal effective concentration: > 10000 nM
Compound 3 ended at the assay's limit (the forecaster's own chance of this, stated with the estimate: 65%); middle value at least 2.5-fold (0.39 log units) away from the limit.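

No step can be read among compound 1, compound 2 and compound 3 in this assay, as all three values are limits of the assay. The compounds shown leave open whether any substituent change at this position alters the concentration needed for the effect.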